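Hydrogen for chloro on compound 1

The compounds below may be only part of what the source reports. "The series", "measured", "known", "first", "only" and "open" are said of these compounds alone.

Measured so far in a functional assay on HCC827 cells (Homo sapiens) for inhibition, read by fluorescence, with a stated time of 72 h (on this read-out higher numbers stand for weaker inhibition of growth and lower numbers for stronger inhibition of growth), are two compounds.
compound 1 `CC(C)CCn1cnc2c(Nc3ccc(Cl)cc3)nc(N[C@H]3CC[C@H](N)CC3)nc21` gives 10200 nM here
compound 2 `N[C@H]1CC[C@H](Nc2nc(Nc3ccc(Cl)cc3)c3ncn(C4CCCCC4)c3n2)CC1` gives 9100 nM here

Compound 1 at 10200 nM stands level with compound 2 within the scatter, and no other measured neighbour exists. Compound 3 `CC(C)CCn1cnc2c(Nc3ccccc3)nc(N[C@H]3CC[C@H](N)CC3)nc21` has not yet been measured. It differs from compound 1 at one place (hydrogen in place of chloro on an aromatic carbon) with hydrogen in place of chloro on an aromatic carbon. Going by the values given here, the one measured step is a 1.1-fold lower number from compound 1 to compound 2 (0.05 log units; within the scatter) and it concerns cyclohexyl in place of isopentyl on an aromatic nitrogen, not the carbon changed here. Among the compounds with values here, it therefore bears only loosely, and no measured step shows what this change does. No shift beyond the scatter is expected in this assay and the range stays wide. The expected step is a 1.0-fold lower number from compound 1 to compound 3 (0.01 log units; within the scatter) in this estimate. Compound 3 is estimated at 10000 nM (expected range 4000 nM to 22000 nM).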

Compound 3, concentration for 50% growth inhibition: 21700 nM
Compound 3: middle estimate off by 2.2-fold (0.34 log units), on the low side; the measured number falls inside the stated range.
By their numbers in this assay, from the lowest: compounds 2 and 1 (each within the scatter of the next); then compound 3.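

In this assay, hydrogen in place of chloro on the six-membered aromatic ring of carbon only gives a 2.1-fold higher number from compound 1 to compound 3 (0.33 log units; beyond the scatter), a modest step, so this position responds to a change where the earlier swap on the aromatic nitrogen had shown nothing beyond the scatter. Here, the 4-chlorophenyl group goes with stronger inhibition of growth than phenyl, though this rests on a single pair carrying isopentyl on the aromatic nitrogen. No evidence at hand bears on what lies behind this step.

The compounds shown leave open whether the same change would have a similar effect in compound 2, which carries cyclohexyl instead of isopentyl. They also leave open how fluoro, methoxy or an amine at this place would compare with chloro and hydrogen.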